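Swapping Methoxy for Methyl on a Weak Binder

A few compounds are considered here, and "the series" means these few. Any claim that something is new, unique, unknown or untested is made for them only; others in the source may bear on it.

Compound 2 `COc1ccccc1-c1cc(F)cc(C(=O)Nc2cccc(C)n2)c1` sits at the edge of what an in vitro assay on HEK-293T cells for displacement of a labelled ligand from metabotropic glutamate receptor 5 (Rattus norvegicus), read by scintillation counting (a lower number here means a stronger inhibitor, a higher number a weaker inhibitor), can report: in this assay compound 2 gives > 10000 nM, a limit rather than a number (the limit of > 10000 nM in this assay, at which 1 of the 2 values shown sits). Compound 1 `Cc1cccc(NC(=O)c2cc(F)cc(-c3cccnc3)c2)n1` gives 702 nM in this assay, so the step of an at least 14-fold higher number from compound 1 to compound 2 (1.15 log units; beyond the scatter) was a large loss. Compound 3 `Cc1cccc(NC(=O)c2cc(F)cc(-c3ccccc3C)c2)n1` differs from compound 2 by methyl in place of methoxy on an aromatic carbon. Among the measured compounds shown here, no measured step tests this change directly; only that large loss bears on it, and it leaves compound 3 on the weak side. Compound 3 is therefore expected to stay weak, with the step of an at least 1.2-fold lower number from compound 2 to compound 3 (0.09 log units; that floor lies within the scatter) estimated as at most a modest gain. The estimate for compound 3 is 8000 nM, within 2000 nM to 30000 nM.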

Compound 3, inhibition constant: 610 nM
For compound 3 the middle estimate is 13-fold (1.12 log units) above the measured one; the measured number lies below the stated range.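

Methyl in place of methoxy gives an at least 16-fold lower number from compound 2 to compound 3 (1.21 log units; beyond the scatter), so the earlier loss does not extend to every ring with a group at this spot: it is tied to methoxy. That step is only a floor, since compound 2 sits at a limit: the limit of > 10000 nM in this assay, at which 1 of the 3 values shown sits. Compound 3 also shows that pyridin-3-yl is not needed at this position, with 2-methylphenyl giving a 1.2-fold lower number from compound 1 to compound 3 (0.06 log units; within the scatter).

Why methoxy costs so much stays unexplained. From the compounds shown here alone, it is also open whether an amine or a chlorine in the same place would behave like methyl or like methoxy.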